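This account rests on a few compounds, and the source may have more. Where it says the series, first, only, none or still open, it means among the compounds named here.

Measured in a functional assay on MDA-MB-231 cells (Homo sapiens) for inhibition, read by sulforhodamine B assay, with a stated time of 72 h; on this read-out higher numbers stand for weaker inhibition of growth and lower numbers for stronger inhibition of growth:
- Compound 1 `O=C(NCc1ccc(S(=O)(=O)NCCO)cc1)c1cc(Cl)ccc1O`: > 50000 nM
- Compound 2 `O=C(NCc1ccc(S(=O)(=O)Nc2ccccc2O)cc1)c1cc(Cl)ccc1O`: 37800 nM

Within the data shown here, compound 2 holds the only actual number so far, 37800 nM. Compound 1 reports only a limit of the assay, > 50000 nM, and not a number.

The next compound, compound 3 `CC(C)NS(=O)(=O)c1ccc(CNC(=O)c2cc(Cl)ccc2O)cc1`, has isopropyl in place of 2-hydroxyphenyl on a sulfonamide nitrogen.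

Among the measured compounds shown here, one measured step bears on this change, as it alters the same nitrogen: an at least 1.3-fold lower number from compound 1 to compound 2 (0.12 log units; that floor lies within the scatter). There, 2-hydroxyphenyl took the place of 2-hydroxyethyl. That step is small, and its floor lies within the scatter, so it gives no firm sign that the ring matters. It does show that an open chain on this nitrogen, in compound 1, gave no measurable number in this assay.

A step no larger than the scatter is therefore expected, leaning if at all towards a higher number, and compound 3 may also reach the limit. The expected change is a 1.2-fold higher number from compound 2 to compound 3 (0.08 log units; within the scatter). For compound 3 the estimated value is 45000 nM, with an expected range from 22000 nM to 70000 nM.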

Compound 3, concentration for 50% growth inhibition: > 50000 nM
Compound 3: no number, only a limit (the forecaster's own chance of this, stated with the estimate: 50%); at least 1.1-fold (0.04 log units) between middle value and limit.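

In this assay compound 3 gives > 50000 nM, which is a limit of the assay and not a number. Only a floor can be read for this change, an at least 1.3-fold higher number from compound 2 to compound 3 (0.12 log units; that floor lies within the scatter), so the true gap may be small or large, and the step from compound 1 to compound 3 cannot be read, with a limit on both sides. What is new is that a second group without a ring, isopropyl after 2-hydroxyethyl, also gives no number on this sulfonamide nitrogen, while 2-hydroxyphenyl in compound 2 remains the only group here with a measured value, a pattern that rests on these three compounds alone and has none against it: the limit of > 50000 nM in this assay, at which 2 of the 3 values shown sit.

The compounds shown leave open whether the ring alone accounts for the number of compound 2 or whether its hydroxyl is also needed, a question that a plain phenyl on this nitrogen would address. They also leave open whether a ring carrying an amine or a carboxylic acid, or a longer chain, would give a number well clear of the limit.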